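Aryl Swap on a Ring Nitrogen of an Inactive Series

This account rests on a few compounds, and the source may have more. Where it says the series, first, only, none or still open, it means among the compounds named here.

compound 1 `C/C(=C\CC/C(C)=C/CC[C@@H]1[C@@]2(C)CCC(=O)C(C)(C)[C@H]2CC[C@@]1(C)O)CC/C=C(\C)C(=O)OCc1cn(-c2ccc([N+](=O)[O-])cc2)nn1`: > 150000 nM
compound 2 `C/C(=C\CC/C(C)=C/CC[C@@H]1[C@@]2(C)CCC(=O)C(C)(C)[C@H]2CC[C@@]1(C)O)CC/C=C(\C)C(=O)OCc1cn(-c2ccccc2C(F)(F)F)nn1`: > 150000 nM
compound 3 `C/C(=C\CC/C(C)=C/CC[C@@H]1[C@@]2(C)CCC(=O)C(C)(C)[C@H]2CC[C@@]1(C)O)CC/C=C(\C)C(=O)OCc1cn(-c2ccccc2C)nn1`: > 150000 nM

In a functional assay on A549 cells (Homo sapiens) for antiproliferative activity, read by MTT assay, with a stated time of 48 h (on this read-out higher numbers stand for weaker inhibition and lower numbers for stronger inhibition), compound 1 gives > 150000 nM, which is a limit of the assay and not a number. Compound 2 gives > 150000 nM, also a limit. Compound 3 gives > 150000 nM, again a limit. Compound 2 thus stands at the limit shared by all three, as the limit of > 150000 nM in this assay, at which 3 of the 3 values shown sit, records. The steps a step that the two limits leave unreadable from compound 1 to compound 2 and a step that the two limits leave unreadable from compound 2 to compound 3 are the ones touching compound 2, and neither has a readable size. Compound 4 `C/C(=C\CC/C(C)=C/CC[C@@H]1[C@@]2(C)CCC(=O)C(C)(C)[C@H]2CC[C@@]1(C)O)CC/C=C(\C)C(=O)OCc1cn(-c2cccc(Cl)c2)nn1` carries 3-chlorophenyl in place of 2-(trifluoromethyl)phenyl on an aromatic nitrogen. With only unreadable steps to draw on, the expected step of a number no higher from compound 2 to compound 4 (the limit leaves the size open) can be given no direction beyond the scatter. Compound 4 is therefore estimated at 150000 nM, with a range from 60000 nM to 400000 nM, most likely reported again as a limit.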

Compound 4, half-maximal inhibitory concentration: 147000 nM
Compound 4: the middle estimate sits 1.0-fold (0.01 log units) above what was measured; measured number inside the range.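

Among the compounds shown here, with 3-chlorophenyl on the aromatic nitrogen, compound 4 gives 147000 nM in this assay, the first value in this set that is a number and not a limit. The steps are an at least 1.0-fold lower number from compound 2 to compound 4 (0.00 log units; that floor lies within the scatter), an at least 1.0-fold lower number from compound 3 to compound 4 (0.00 log units; that floor lies within the scatter) and an at least 1.0-fold lower number from compound 1 to compound 4 (0.00 log units; that floor lies within the scatter), so no gain from this aryl swap can be claimed beyond the scatter. Compound 1, compound 2 and compound 3 remain limits of the assay: the limit of > 150000 nM in this assay, at which 3 of the 4 values shown sit.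

From the compounds shown here alone, how far those three compounds lie past their limit stays open. Also open, going by these compounds, is whether a phenyl bearing an amine or a carboxylic acid, or a longer alkyl chain, on this ring nitrogen would move the number.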